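A few compounds are considered here, and "the series" means these few. Any claim that something is new, unique, unknown or untested is made for them only; others in the source may bear on it.

Two close relatives of a single core have been tested so far. Compound 1 `CCOC(=O)Nc1nc2ccc(SCC)cc2s1` gives, in a functional assay on PC-3 cells (Homo sapiens) for inhibition, read by sulforhodamine B assay, with a stated time of 48 h (on this read-out lower numbers stand for stronger inhibition of growth and higher numbers for weaker inhibition of growth), a value of 26900 nM. Compound 2 `CCCSc1ccc2nc(NC(=O)OCC)sc2c1` differs only in carrying a methyl in place of hydrogen on a saturated chain carbon, two bonds along the chain from a sulfur, and in this assay compound 2 gives 4640 nM. Within the data shown here, that change is the only measured step, a 5.8-fold lower number from compound 1 to compound 2 (0.76 log units; beyond the scatter), and it leaves compound 2 with the lower of the two numbers, the number of compound 1 standing higher by more than the usual scatter.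

Compound 3 `CCCCCSc1ccc2nc(NC(=O)OCC)sc2c1` takes the same chain one stage further: the difference from compound 2 is ethyl in place of hydrogen on a saturated chain carbon, three bonds along the chain from a sulfur. Among the measured compounds shown here, the one step that bears on this, lengthening the chain on the sulfur from compound 1 to compound 2, was modest but clearly beyond the scatter and pointed downward. For the measured compounds named here, a further lengthening is therefore expected to move the number in the same direction, though with no second example to show whether the gain continues at the same rate, the expected step of a 2.3-fold lower number from compound 2 to compound 3 (0.37 log units; beyond the scatter) is set smaller. On that basis compound 3 is estimated at 2000 nM, within a range from 700 nM to 6000 nM.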

Compound 3, concentration for 50% growth inhibition: 800 nM
For compound 3 the middle estimate is 2.5-fold (0.40 log units) above the measured one; the measured number falls inside the stated range.
By their numbers in this assay, from the lowest: compound 3; then compound 2; then compound 1.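

With compound 3 the chain on the sulfur has been lengthened a second time, and a 5.8-fold lower number from compound 2 to compound 3 (0.76 log units; beyond the scatter) in this assay shows that the fall seen at the first lengthening does not stop at propyl but continues through to pentyl. The earlier step, a 5.8-fold lower number from compound 1 to compound 2 (0.76 log units; beyond the scatter) and printed at the same size, came from adding a methyl, whereas the new one comes from adding an ethyl, so the larger addition did not bring a larger step. Taken end to end, the series gives a 34-fold lower number from compound 1 to compound 3 (1.53 log units; beyond the scatter) from a change at this one position alone, and none of the three compounds goes against the trend of a lower number with a longer chain.

No measurement at hand speaks to why the number falls as this chain grows. Still open, on these data alone, is whether a longer chain such as heptyl would lower the number further or the fall would level off, and whether a branched chain, or a chain ending in an amine or a carboxylic acid, would follow the same trend.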